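The compounds below may be only part of what the source reports. "The series", "measured", "known", "first", "only" and "open" are said of these compounds alone.

Measured so far:
- compound 1 `O=C(NC1CCN(c2ncnc3[nH]ncc23)CC1)c1ccc(C(F)(F)F)cc1`: 5740 nM
- compound 2 `Cc1cccc(C)c1NC(=O)NC1CCN(c2ncnc3[nH]ncc23)CC1`: 2160 nM

For the measured compounds named here, in an assay on isolated protein for inhibition of serine/threonine-protein kinase PAK 1 (Homo sapiens), read by ADP-Glo, with a stated time of 40 min (on this read-out higher numbers stand for weaker inhibition and lower numbers for stronger inhibition), compound 2 gives the lowest of the two numbers so far; its nearest neighbour is compound 1, whose number stands higher by a gap that lies beyond the usual scatter. Going by the values given here, compound 1 is an amide and compound 2 a urea, and they carry different aryl groups as well, so no single-point step between measured compounds is available.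

Compound 3 `O=C(Nc1ccc(F)cc1F)NC1CCN(c2ncnc3[nH]ncc23)CC1` is the next compound to be measured. It differs from compound 2 in one place: 2,4-difluorophenyl in place of 2,6-dimethylphenyl on an amide-type nitrogen. Both aryl groups are of the same size and carry neither hydrogen-bond donors nor acceptors, and the urea and the shared core are kept. Among the compounds with values here, with no measured step of this kind to lean on, the expectation is for a change in this assay that stays within or close to the scatter, with no clear direction.

For compound 3 the estimated value in this assay is 2600 nM (range 800 nM to 8500 nM), which is expected to mean a step of a 1.2-fold higher number from compound 2 to compound 3 (0.08 log units; within the scatter).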

Compound 3, half-maximal inhibitory concentration: 1140 nM
The estimate for compound 3 lay 2.3-fold (0.36 log units) above the measured number; the measured number falls inside the stated range.
By their numbers in this assay, from the lowest: compounds 3 and 2 (each within the scatter of the next); then compound 1.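

In this assay, 2,4-difluorophenyl in place of 2,6-dimethylphenyl on an amide-type nitrogen gives a 1.9-fold lower number from compound 2 to compound 3 (0.28 log units; within the scatter), the first single-point step available in this series. At this position, with the urea and the shared core kept, the read-out therefore does not separate these two aryl groups, even though one carries only carbon and the other carries fluorine, so the substitution patterns compared here are interchangeable within the scatter for this pair alone. No measurement on hand bears on why the two compounds read alike.

Still open, from the compounds shown here alone, is whether any group at this position can move the number beyond the scatter: an aryl ring bearing an amine or a carboxylic acid, a pyridine in place of the phenyl ring, or a longer chain between the urea and the ring would each test this. Also open, going by these compounds, is the contribution of the urea relative to the amide, as compound 1 differs from compound 2 and compound 3 in both that linkage and its aryl group, and a comparison of an amide and a urea carrying the same aryl group would be needed to separate the two.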